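The source may report more compounds than this note shows. Statements on the series, on what has been measured and on what is new or still open speak of the compounds shown alone.

Compound 1 `O=C(Nc1ccc(Oc2cc(C(F)(F)F)cc(C(F)(F)F)c2)cc1)c1c(O)cccc1F` belongs to this series, but in an assay on HEK293 cells for inhibition of Toll-like receptor 8 (Homo sapiens), with a stated time of 16 h (on this read-out lower numbers stand for stronger inhibition and higher numbers for weaker inhibition), compound 1 gives "not determined" (no result reported). Going by the values given here, compound 2 `Nc1ccc(C(=O)Nc2ccc(Oc3cc(C(F)(F)F)cc(C(F)(F)F)c3)cc2)c(F)c1` is the only member with a recorded result. In this assay compound 2 gives > 50000 nM, which is a limit of the assay rather than a number. Among the two entries shown, compound 2 sits at the limit of > 50000 nM in this assay, at which 1 of the 2 values shown sits, and the other entry carries no single number, so compound 2 cannot be placed against any measured neighbour. Compound 3 `O=C(Nc1ccc(Oc2cc(C(F)(F)F)cc(C(F)(F)F)c2)cc1)c1c(F)cccc1OC(F)(F)F` has not yet been measured. It differs from compound 2 by a group of 12 heavy atoms (7 carbon, 1 oxygen, 4 fluorine; one six-membered aromatic ring of carbon only) in place of a group of 8 heavy atoms (6 carbon, 1 nitrogen, 1 fluorine; one six-membered aromatic ring of carbon only), on a carbonyl carbon. Among the compounds with values here, no step between two measured compounds is available here, so the size of the change going to compound 3 has no measured counterpart. Compound 3 is expected to remain weak, with a step from compound 2 of an at least 1.1-fold lower number from compound 2 to compound 3 (0.04 log units; that floor lies within the scatter) that stays within the scatter, because compound 2 gives > 50000 nM and only a limit is known. Compound 3 is therefore estimated at 45000 nM in this assay, within a range from 10000 nM to 120000 nM, with a considerable chance that only a limit is again reported.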

Compound 3, half-maximal inhibitory concentration: > 50000 nM
Compound 3 ended at the assay's limit (the forecaster's own chance of this, stated with the estimate: 60%); at least 1.1-fold (0.04 log units) between middle value and limit.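

In this assay compound 3 gives > 50000 nM, which is a limit of the assay and not a number. Going by these compounds alone, compound 2 also stands at a limit, so no step between compound 2 and compound 3 can be read. The compounds shown leave open whether the group on the carbonyl carbon affects inhibition at all: they hold no single number in this assay.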